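Swapping an anilide for a benzylamide: will anything change?

The source may hold more compounds than are shown below. What is called first, only, known or untested is meant among the compounds shown, and "the series" means these compounds.

Three analogues of one shared core have been tested so far in a functional assay on SW480 cells (Homo sapiens) for cytotoxicity, read by MTT assay, with a stated time of 24 h; on this read-out higher numbers stand for weaker inhibition and lower numbers for stronger inhibition. Compound 1 `C=CC1=C(C(=O)NCc2ccc(Cl)cc2)C(c2ccc(OC)c(OC)c2)OC1` gives > 100000 nM, which is a limit of the assay rather than a number. Compound 3 `C=CC1=C(C(=O)NCc2ccc(Cl)cc2)C(c2ccc(OC)cc2)OC1`, with hydrogen in place of methoxy on an aromatic carbon, likewise gives > 100000 nM, again a limit. The step between them, a step that the two limits leave unreadable from compound 1 to compound 3, therefore cannot be sized. Compound 2 `C=CC1=C(C(=O)Nc2ccccc2)C(c2ccc(Cl)c(Cl)c2)OC1` also reaches only a limit in this assay, > 100000 nM. All three results thus sit at the same edge, as summed up by the limit of > 100000 nM in this assay, at which 3 of the 3 values shown sit.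

The unmeasured compound 4 `C=CC1=C(C(=O)NCc2ccccc2)C(c2ccc(Cl)c(Cl)c2)OC1` differs from compound 2 by benzyl in place of phenyl on an amide-type nitrogen. Going by the values given here, no measured step isolates this change, so its effect cannot be read from the data. What the data do show is that the two compounds already carrying the benzyl amide, compound 1 and compound 3, sit at the limit just as compound 2 does. Compound 4 is therefore expected to stay at that edge, with a step that the limit leaves unreadable from compound 2 to compound 4 meaning no shift beyond scatter. The estimate for compound 4 is 150000 nM, within a range from 50000 nM to 500000 nM, most likely reported again only as a limit.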

Compound 4, half-maximal inhibitory concentration: > 100000 nM
Compound 4 gave a limit, no number; the forecaster's own chance of this, stated with the estimate: 85%; the middle value is on the limit's open side.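

Going by these compounds alone, the change from compound 2 to compound 4 gives no step that can be read, because both compounds stop at a limit of the assay rather than a number: the limit of > 100000 nM in this assay, at which 4 of the 4 values shown sit.

The compounds shown leave open how far past that limit each one lies, and whether any analogue of the shared core gives a true number in this assay at all.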